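Aryl thioether variation on a shared core

A few compounds are considered here, and "the series" means these few. Any claim that something is new, unique, unknown or untested is made for them only; others in the source may bear on it.

Compound 1 `CC(O)(CSc1ccc(C(F)(F)F)cc1)C(=O)Nc1cccc(S(F)(F)(F)(F)F)c1` gives 26900 nM in a functional assay on CWR22R cells (Homo sapiens) for antiproliferative activity, read by propidium iodide staining, with a stated time of 96 h; on this read-out lower numbers stand for stronger inhibition and higher numbers for weaker inhibition. Compound 2 `CC(O)(CSc1cccc(C(F)(F)F)c1)C(=O)Nc1cccc(S(F)(F)(F)(F)F)c1` differs from compound 1 by 3-(trifluoromethyl)phenyl in place of 4-(trifluoromethyl)phenyl on a sulfur, and in this assay compound 2 gives 12900 nM, a step of a 2.1-fold lower number from compound 1 to compound 2 (0.32 log units; beyond the scatter). Compound 3 `CC(O)(CSc1ccc(OC(F)(F)F)cc1)C(=O)Nc1cccc(S(F)(F)(F)(F)F)c1` carries trifluoromethoxy in place of trifluoromethyl on an aromatic carbon relative to compound 1, and in this assay compound 3 gives 17000 nM; the step of a 1.6-fold lower number from compound 1 to compound 3 (0.20 log units; within the scatter) stays within the usual scatter. Compound 4 `CC(O)(CSc1cccc(OC(F)(F)F)c1)C(=O)Nc1cccc(S(F)(F)(F)(F)F)c1` is not yet measured and differs from compound 2 by trifluoromethoxy in place of trifluoromethyl on an aromatic carbon. This is the same kind of change as between compound 1 and compound 3, though the place is not identical: para to a large group in the earlier pair, meta to a large group here. For compound 4 the expected step is a 1.4-fold lower number from compound 2 to compound 4 (0.16 log units; within the scatter). That expectation rests only on the earlier step of a 1.6-fold lower number from compound 1 to compound 3 (0.20 log units; within the scatter), itself within the scatter. Compound 4 is therefore estimated at 9000 nM, between 4000 nM and 25000 nM.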

Compound 4, half-maximal inhibitory concentration: 18700 nM
Beside the measured number, compound 4's estimate is 2.1-fold (0.32 log units) below it; the range from low to high includes it.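

In this assay, trifluoromethoxy in place of trifluoromethyl on an aromatic carbon meta to a large group gives a 1.4-fold higher number from compound 2 to compound 4 (0.16 log units; within the scatter). The same change on the two cores gives steps that cannot be told apart: the same change on two cores in this assay, a 1.6-fold lower number (0.20 log units; within the scatter) from compound 1 to compound 3 and a 1.4-fold higher number (0.16 log units; within the scatter) from compound 2 to compound 4, 2.3-fold (0.36 log units) apart, within the scatter of two such steps. Across these two pairs the change stays within the scatter on both cores, but this shows neither a real gain or loss on either core nor how the change would behave on any further core.

Still open, going by these compounds, is whether other groups on this aromatic carbon, such as a nitrile, a chlorine atom or an amine, would move the number beyond the scatter. Also open, on these data alone, is the effect of a sulfone in place of the thioether sulfur.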